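The source may report more compounds than this note shows. Statements on the series, on what has been measured and on what is new or still open speak of the compounds shown alone.

For the measured compounds named here, in a functional assay on MCF7 cells (Homo sapiens) for inhibition, read by MTT assay, with a stated time of 48 h (a higher number here means a weaker inhibitor, a lower number a stronger inhibitor), three compounds have numbers so far. Compound 1, `COc1cc(N(Cc2ccc(Br)cc2)S(=O)(=O)c2ccc(C)cc2)cc(OC)c1OC`, gives 10900 nM. Compound 2, `Cc1ccc(S(=O)(=O)N(Cc2nc3ccccc3[nH]2)c2ccc(F)cc2)cc1`, reaches only the limit of the assay, > 50000 nM. Compound 3, `Cc1ccc(S(=O)(=O)N(Cc2nc3ccccc3[nH]2)c2ccc(Cl)cc2)cc1`, gives 38300 nM, and on the numbers shown compound 3 stands highest, with compound 1 a good deal lower. Going by the values given here, the step of an at least 1.3-fold lower number from compound 2 to compound 3 (0.11 log units; that floor lies within the scatter) is the only measured change at this place on the ring; its floor is set by the limit, (the limit of > 50000 nM in this assay, at which 1 of the 3 values shown sits), so its true size is not known.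

Compound 4, `Cc1ccc(S(=O)(=O)N(Cc2nc3ccccc3[nH]2)c2ccccc2)cc1`, differs from compound 3 by hydrogen in place of chloro on an aromatic carbon. Among the compounds with values here, no measured pair shows this removal of the chloro group directly. Within the data shown here, the one step that bears on it, an at least 1.3-fold lower number from compound 2 to compound 3 (0.11 log units; that floor lies within the scatter), shows chloro in place of fluoro giving a lower number; going the other way, to no substituent at all, the number is expected to rise, and quite possibly past the limit. Compound 4 is therefore estimated at 50000 nM, within 20000 nM to 150000 nM. That estimate means a step of a 1.3-fold higher number from compound 3 to compound 4 (0.12 log units; within the scatter) from compound 3 to compound 4, expected to be upward, though only modestly beyond the scatter and with a real chance that the assay reports a limit rather than a number.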

Compound 4, half-maximal inhibitory concentration: 49700 nM
Compound 4: middle estimate off by 1.0-fold (0.00 log units), on the high side, within the range that was stated.
By their numbers in this assay, from the lowest: compound 1; then compounds 3 and 4 (each within the scatter of the next). At a limit, above all of these: compound 2.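

For the compounds shown here, replacing the chloro group with hydrogen gives the first pair at this place with a real number at both ends, and in this assay it reads as a 1.3-fold higher number from compound 3 to compound 4 (0.11 log units; within the scatter). On an aromatic carbon para to a large group, the 4-chlorophenyl to phenyl change therefore does not move the number beyond the scatter, so in this pair the chloro group makes no measurable difference. The other step, a number no higher from compound 2 to compound 4 (the limit leaves the size open), cannot be read, because its starting value is a limit rather than a number: the limit of > 50000 nM in this assay, at which 1 of the 4 values shown sits.

Whether any other group at this place, such as a methoxy, an amine or a carboxylic acid, would shift the number beyond the scatter remains open, as the only groups shown here on this carbon are hydrogen and two halogens. Compound 1, at 10900 nM, differs from compound 3 and compound 4 in more than one place, so which of its differences accounts for its number also remains open.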